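Aryl sulfonyl variation on the shared core

This account rests on a few compounds, and the source may have more. Where it says the series, first, only, none or still open, it means among the compounds named here.

Three aryl sulfonyl analogues of the shared core have been run in a functional assay on the whole organism (strain Jcl:Sprague-Dawley) for inhibition, with Rattus norvegicus as the target, with stated times of 3 min and 3 h, at a dose of 1 mg/kg by the intravenous route; on this read-out higher numbers stand for more inhibition at the one dose given (going by the name of the read-out) and lower numbers for less inhibition. Compound 1 `CNCc1cn(S(=O)(=O)c2ccoc2)c(-c2cccnc2F)c1F` gives 95%, compound 2 `CNCc1cn(S(=O)(=O)c2ccccn2)c(-c2cccnc2F)c1F` gives 95%, and compound 3 `CNCc1cn(S(=O)(=O)c2cncc(F)c2)c(-c2cccnc2F)c1F` gives 99%. Compound 2 stands level with compound 1, the two together forming the lower pair of the three; compound 3 is the furthest from it, by a number 4 percentage points higher from compound 2 to compound 3 (within the scatter). The remaining steps are no change at the digits printed from compound 1 to compound 2 (within the scatter) and a number 4 percentage points higher from compound 1 to compound 3 (within the scatter).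

Compound 4 `CNCc1cn(S(=O)(=O)c2ccc(C)nc2)c(-c2cccnc2F)c1F` differs from compound 2 by 6-methylpyridin-3-yl in place of pyridin-2-yl on a sulfonyl sulfur. All three measured aryl exchanges on the sulfonyl sulfur stayed within the scatter, so no movement beyond the scatter is expected here either, and the estimated step is no change at the digits printed from compound 2 to compound 4 (within the scatter). Compound 4 is accordingly expected at about 95%, in the range 85% to 99%.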

Compound 4, a percentage reported as inhibition, in the whole organism at one dose (the size of the read-out at that dose, not a potency): 97%
Beside the measured number, compound 4's estimate is 2 percentage points below it; measured number inside the range.
By their numbers in this assay, from the lowest: compounds 1, 2, 4 and 3 (each within the scatter of the next).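

Swapping in 6-methylpyridin-3-yl extends the flat picture on the sulfonyl sulfur to a ring bearing a methyl group in this assay: a number 2 percentage points higher from compound 2 to compound 4 (within the scatter), a number 2 percentage points lower from compound 3 to compound 4 (within the scatter) and a number 2 percentage points higher from compound 1 to compound 4 (within the scatter). The position thus holds 7 heavy atoms in place of the 6 of pyridin-2-yl with no step beyond the scatter. No supporting data bear on why this read-out stays flat.

Still open, going by these compounds, is whether a pyridine carrying an amine or a carboxylic acid would hold this level. The same applies to a non-aromatic group such as methyl or a longer alkyl chain on the sulfonyl sulfur.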